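Ring in place of methyl on the amide nitrogen

The source may hold more compounds than are shown below. What is called first, only, known or untested is meant among the compounds shown, and "the series" means these compounds.

Compound 3: `CNC(=O)/C=C1\CCc2ccc(F)cc21`, 50%
Compound 1: `O=C(/C=C1\CCc2ccc(F)cc21)NC1CCCC1`, 0%
Compound 2: `O=C(/C=C1\CCc2ccc(F)cc21)NCc1ccccc1`, 17%

In a functional assay on the whole organism with Mus musculus as the target, at a dose of 100 mg/kg by the intraperitoneal route (a higher number here means more inhibition at the dose given (going by the name of the read-out), a lower number less inhibition), compound 3 gives the highest of the three numbers; compound 2 lies a number 33 percentage points higher from compound 2 to compound 3 (beyond the scatter) and compound 1 lies a number 50 percentage points higher from compound 1 to compound 3 (beyond the scatter). Compound 4 is `O=C(/C=C1\CCc2ccc(F)cc21)NC1CCC1`, differing from compound 3 by cyclobutyl in place of methyl on an amide-type nitrogen. The step that bears on it runs from cyclopentyl to methyl, a number 50 percentage points higher from compound 1 to compound 3 (beyond the scatter), and the benzyl analogue also stayed low, a number 17 percentage points higher from compound 1 to compound 2 (beyond the scatter). Since the group entering is again a ring on the amide nitrogen, a fall is expected, a number 30 percentage points lower from compound 3 to compound 4 (beyond the scatter). Compound 4 is therefore estimated at 20%, within 0% to 45%.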

Compound 4, a percentage reported as inhibition, in the whole organism at one dose (the size of the read-out at that dose, not a potency): 100%
Estimate against measurement, compound 4: 80 percentage points below, outside the stated range (above it).
By their numbers in this assay, from the lowest: compound 1; then compound 2; then compound 3; then compound 4.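

In this assay a ring on the amide-type nitrogen does not by itself lower the number: cyclobutyl in place of cyclopentyl gives a number 100 percentage points higher from compound 1 to compound 4 (beyond the scatter) and so the identity of the ring matters here. Cyclobutyl also exceeds both the methyl and the benzyl, with a number 50 percentage points higher from compound 3 to compound 4 (beyond the scatter) and a number 83 percentage points higher from compound 2 to compound 4 (beyond the scatter) at this same position. Nothing given here accounts for this result.

Going by these compounds, it remains open how cyclopropyl or cyclohexyl on this nitrogen would compare with cyclobutyl. On these data alone, it also remains open whether an open chain such as isopropyl would match it.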